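Swapping a dichlorophenoxy group for a fluorophenoxy group

A few compounds are considered here, and "the series" means these few. Any claim that something is new, unique, unknown or untested is made for them only; others in the source may bear on it.

Compound 1 `Nc1cc(N)c2nc(-c3ccccc3)c(Oc3ccc(Cl)c(Cl)c3)nc2c1` was tested in a functional assay on HOP-62 cells (Homo sapiens) for inhibition, read by sulforhodamine B assay, with a stated time of 48 h (on this read-out lower numbers stand for stronger inhibition of growth and higher numbers for weaker inhibition of growth), where compound 1 gives 38000 nM. Of the two plain numbers shown, this is the lower one; its nearest neighbour, compound 3 `CCOC(=O)[C@H](CCC(=O)O)NC(=O)c1ccc(Oc2nc3cc(N)cc(N)c3nc2-c2ccccc2)cc1`, gives 87100 nM in this assay, a gap beyond the usual scatter. For compound 2 `CCOC(=O)[C@H](CCC(=O)O)NC(=O)c1ccc(CNc2nc3cc(N)cc(N)c3nc2-c2ccccc2)cc1` only a limit of the assay is reported, < 100000 nM.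

Compound 4 `Nc1cc(N)c2nc(-c3ccccc3)c(Oc3ccc(F)cc3)nc2c1` has not yet been measured. It differs from compound 1 by 4-fluorophenyl in place of 3,4-dichlorophenyl on an oxygen on an aromatic ring. Going by the values given here, no measured pair shows a change of this kind, so the expectation rests on compound 1 alone. The step from compound 1 to compound 4 is expected to be a 1.6-fold higher number from compound 1 to compound 4 (0.20 log units; within the scatter), a modest weakening that may not exceed the scatter. Compound 4 is estimated at 60000 nM, with a range from 20000 nM to 150000 nM.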

Compound 4, concentration for total growth inhibition: 49000 nM
The estimate for compound 4 lay 1.2-fold (0.09 log units) above the measured number; the measured number falls inside the stated range.
By their numbers in this assay, from the lowest: compounds 1, 4 and 3 (each within the scatter of the next, the first and the last beyond it).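

In this assay, going by these compounds alone, this is the first direct comparison at this place: 4-fluorophenyl in place of 3,4-dichlorophenyl on the oxygen gives a 1.3-fold higher number from compound 1 to compound 4 (0.11 log units; within the scatter). Two quite different halogen patterns on this phenyl ring therefore cannot be told apart by this read-out, so this swap alone offers no gain in growth inhibition. Nothing measured here explains why the two compounds read alike.

Still open, on these data alone, is whether a methoxy group or a nitrile on this phenyl ring would move the number beyond the scatter. As far as these compounds go, how a ring carrying a single chlorine would compare also remains unknown.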